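A few compounds are considered here, and "the series" means these few. Any claim that something is new, unique, unknown or untested is made for them only; others in the source may bear on it.

Working notes on the series. Compound 1 `C(=C/c1nn2c(-c3ccncc3)nnc2s1)\c1ccco1` stands highest of the two compounds measured in an assay for inhibition of histone-lysine N-methyltransferase, H3 lysine-79 specific (Homo sapiens), read by scintillation counting, with stated times of 15 min and 60 min, tested at 100 uM, in the presence of a further agent that is not named here; on this read-out higher numbers stand for a stronger effect at the one concentration tested and lower numbers for a weaker effect: in that assay compound 1 gives 82%. Among the measured compounds shown here, the other measured compound, compound 2 `Cc1occc1-c1nnc2sc(Cc3ccccc3)nn12`, gives 24% in this assay, a number well below that of compound 1 and beyond the scatter; compound 2 differs from compound 1 in more than one place, so no single step is defined between the two and their pair only shows two values.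

Compound 3 `C(=C/c1nn2c(-c3ccccc3)nnc2s1)\c1ccco1` is not yet measured. It differs from compound 1 in one place: phenyl in place of pyridin-4-yl on an aromatic carbon. The shared core of compound 1 is otherwise kept.

For the measured compounds named here, no step between measured compounds speaks to this exchange, so its size cannot be read from the numbers at hand. With the read-out of compound 1 already high at 82%, the expectation is a step of modest size, most likely a small loss, possibly none beyond the scatter. The step of a number 12 percentage points lower from compound 1 to compound 3 (beyond the scatter) is the one this estimate means. In this assay compound 3 is expected to give 70%, with a range from 45% to 90%.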

Compound 3, a percentage reported as inhibition, at one concentration (the size of the read-out at that concentration, not a potency): 81%
Estimate against measurement, compound 3: 11 percentage points below; the range from low to high includes it.
By their numbers in this assay, from the lowest: compound 2; then compounds 3 and 1 (each within the scatter of the next).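

In this assay, among the compounds shown here, the exchange of pyridin-4-yl for phenyl on this aromatic carbon, between two ring nitrogen atoms, gives the first defined single step: a number 1 percentage points lower from compound 1 to compound 3 (within the scatter). At the one concentration tested, the ring nitrogen and the hydrogen-bond acceptor counted for pyridin-4-yl are therefore not needed to keep the read-out of compound 3 level with that of compound 1, and a six-membered aromatic ring of carbon only serves equally well at this position. No measurement at hand gives a reason for this result.

For the compounds shown here, the pair tests only two six-membered aromatic rings of equal heavy-atom count, so it remains open whether a carboxylic acid, a primary amine, a morpholine ring or a longer alkyl chain on the same carbon would keep the read-out. Going by these compounds alone, also open is how much the furan-bearing side of the shared core contributes, since compound 2 differs from compound 1 in more than one place and no single step isolates that part, and these single-concentration read-outs do not rank potency.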